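The compounds below may be only part of what the source reports. "The series", "measured", "known", "first", "only" and "open" are said of these compounds alone.

Among the compounds with values here, in an ADME assay (liver) for metabolic stability, with Liver microsome (Homo sapiens) as the target, using microsomes (a lower number here means slower removal, a higher number faster removal of the compound), compound 2 `Cc1cc2c(Oc3cnc(C(=O)N4CC(C)(C)C4)cn3)cc(C(=O)Nc3cnccn3)cc2o1` gives 21.2 mL/min/kg, the only actual number so far. Compound 1 `Cc1cc2c(Oc3cnc(C(=O)N4CC(C)C4)cn3)cc(C(=O)Nc3cnccn3)cc2o1` gives < 9.6 mL/min/kg, which is a limit. Next is compound 3 `COC1CN(C(=O)c2cnc(Oc3cc(C(=O)Nc4cnccn4)cc4oc(C)cc34)cn2)C1`, with the change 3-methoxyazetidin-1-yl in place of 3,3-dimethylazetidin-1-yl on a carbonyl carbon. Within the data shown here, the sole measured step bearing on this is an at least 2.2-fold higher number from compound 1 to compound 2 (0.34 log units; beyond the scatter), a methyl in place of hydrogen on a saturated ring carbon. That is a different change and only a loose guide, but a modest move to a lower number is expected. The expected step is a 1.8-fold lower number from compound 2 to compound 3 (0.25 log units; within the scatter). For compound 3 the estimated clearance is 12 mL/min/kg, with an expected range of 7 mL/min/kg to 22 mL/min/kg.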

Compound 3, clearance: < 9.2 mL/min/kg
Compound 3 gave a limit, no number; the forecaster's own chance of this, stated with the estimate: 35%; middle value at least 1.3-fold (0.11 log units) away from the limit.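

In this assay, the value of compound 3 is a limit, yet it still gives a readable result at this carbonyl carbon: an at least 2.3-fold lower number from compound 2 to compound 3 (0.36 log units; beyond the scatter). The 3,3-dimethylazetidin-1-yl group of compound 2 now has a step beyond the scatter on both sides, since the earlier step was an at least 2.2-fold higher number from compound 1 to compound 2 (0.34 log units; beyond the scatter). Swapping in 3-methoxyazetidin-1-yl, with its same count of heavy atoms, thus also gives a lower number.

The step between compound 1 and compound 3 cannot be read, as both values are limits. Open, going by these compounds, is how a 3-hydroxyazetidin-1-yl, a 3-aminoazetidin-1-yl or a pyrrolidin-1-yl amide would read here.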